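A few compounds are considered here, and "the series" means these few. Any claim that something is new, unique, unknown or untested is made for them only; others in the source may bear on it.

In a functional assay on HL-60 cells (Homo sapiens) for cytotoxicity, read by MTT assay, with a stated time of 48 h (a higher number here means a weaker inhibitor, a lower number a stronger inhibitor), compound 1 `CC(C)c1cccc(OC(=O)c2cn(-c3ccccc3)nc2-c2cccnc2)c1` gives 23700 nM. Compound 2 `Cc1ccc(C(C)C)c(OC(=O)c2cn(-c3ccccc3)nc2-c2cccnc2)c1` gives 22700 nM in this assay. The step of a 1.0-fold lower number from compound 1 to compound 2 (0.02 log units; within the scatter) is the only measured one, and it concerns an ester group. Compound 3 `O=C(NCc1ccccc1)c1cn(-c2ccccc2)nc1-c1ccncc1` reaches only a limit in this assay, reported as > 100000 nM, which is the limit of > 100000 nM in this assay, at which 1 of the 3 values shown sits. Compound 4 `O=C(O)c1cn(-c2ccccc2)nc1-c1ccncc1` differs from compound 3 by hydroxy in place of benzylamino on a carbonyl carbon. Among the measured compounds shown here, no measured step bears on this change, since the step of a 1.0-fold lower number from compound 1 to compound 2 (0.02 log units; within the scatter) touches another part of the molecule. Starting from a limit, no gain beyond the scatter is expected, and the step of a number no higher from compound 3 to compound 4 (the limit leaves the size open) is an estimate only. Compound 4 is therefore expected to give 100000 nM in this assay, within 40000 nM to 300000 nM.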

Compound 4, half-maximal inhibitory concentration: > 100000 nM
Compound 4 ended at the assay's limit; the forecaster's own chance of this, stated with the estimate: 70%; the middle value sits exactly at the limit.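

Compound 3 and compound 4 both stand at a limit in this assay, so no step between them can be read: the limit of > 100000 nM in this assay, at which 2 of the 4 values shown sit.

The compounds shown leave open whether hydroxy and benzylamino on the carbonyl carbon differ in this assay at all, and by how much.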